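The source may report more compounds than this note shows. Statements on the series, on what has been measured and on what is new or still open speak of the compounds shown alone.

Measured compounds:
- compound 1 `N/C(=N\NC(=S)N1CCCCCC1)c1ccccn1`: 21.3%
- compound 2 `Cc1cccc(/C(N)=N/NC(=S)N2CCCCCC2)n1`: 49.5%

In a functional assay on HeLa cells (Homo sapiens) for cytotoxicity, read by MTT assay, with a stated time of 72 h, tested at 1 uM (on this read-out lower numbers stand for less inhibition of growth and higher numbers for more inhibition of growth at the one concentration tested), compound 1 gives 21.3%, the lower of the two numbers on hand. Within the data shown here, compound 2 stands higher, and the single measured step, a number 28.2 percentage points higher from compound 1 to compound 2 (beyond the scatter), exceeds the scatter of this assay.

Compound 3 `N/C(=N\NC(=S)N1CCCCCC1)c1ccc(F)cn1` is the next member of the series and has not yet been run in this assay. It differs from compound 1 in one place: fluoro in place of hydrogen on an aromatic carbon.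

Among the measured compounds shown here, only one step bears on this: the methyl-for-hydrogen change from compound 1 to compound 2, which was modest in size and upward. It concerns a different group at a different ring carbon, so it gives a direction but no firm size for fluoro. The expectation for compound 3 is therefore a step of a number 8.7 percentage points higher from compound 1 to compound 3 (within the scatter), a small rise in growth inhibition, with no certainty that it clears the scatter. On that basis compound 3 is estimated at 30% in this assay, within a range from 10% to 52%.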

Compound 3, percent growth inhibition at one concentration: 50%
Compound 3: the middle estimate sits 20 percentage points below what was measured; low and high end bracket the measured number.
By their numbers in this assay, from the lowest: compound 1; then compounds 2 and 3 (each within the scatter of the next).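

In this assay, the carbon two atoms from the ring nitrogen and para to a large group proves responsive: a single fluoro in place of hydrogen, one heavy atom with no hydrogen-bond donors or acceptors, gives a number 28.7 percentage points higher from compound 1 to compound 3 (beyond the scatter) and so clears the scatter, which the earlier compounds gave no reason to assume for this carbon. The core of compound 1 has now shown a rise beyond the scatter with two different ring substituents, since methyl in place of hydrogen at another ring carbon gives a number 28.2 percentage points higher from compound 1 to compound 2 (beyond the scatter), and neither step goes against that upward direction. No measurement on hand accounts for the rise seen with fluoro.

The compounds shown leave open whether the rise belongs to fluoro itself or to any substituent on this carbon, a question that a chloro group, a methoxy group or an amine in the same place would help to settle. Also open, as far as these compounds go, is how the rise at the one concentration tested relates to a full concentration-response curve for these compounds on HeLa cells.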